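The source may report more compounds than this note shows. Statements on the series, on what has been measured and on what is new or still open speak of the compounds shown alone.

Compound 1 `Cc1nc(S(C)(=O)=O)ccc1Oc1ncnc(OC2CCN(C(=O)OC(C)(C)C#N)CC2)c1F` is the starting point. In a functional assay on isolated protein for inhibition of Glucose-dependent insulinotropic receptor (Rattus norvegicus), read by HTRF and cAMP accumulation (a higher number here means a larger maximal response, a lower number a smaller maximal response), compound 1 gives 97%, the highest of the three measured numbers. Two other compounds share its core and differ from it only in the group carried on the carbonyl carbon attached to the ring nitrogen. Compound 2 `Cc1nc(S(C)(=O)=O)ccc1Oc1ncnc(OC2CCN(C(=O)SC(C)(C)C)CC2)c1F` gives 76% in this assay, and compound 3 `Cc1nc(S(C)(=O)=O)ccc1Oc1ncnc(OC2CCN(C(=O)C(C)(C)F)CC2)c1F` gives 74%.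

Compound 4 `CCC(F)(F)C(=O)N1CCC(Oc2ncnc(Oc3ccc(S(C)(=O)=O)nc3C)c2F)CC1` has not yet been measured. It differs from compound 1 in one place: 1,1-difluoropropyl in place of 1-cyano-1-methylethoxy on a carbonyl carbon

Both measured steps away from compound 1 bear on this change, since each of them also removes the 1-cyano-1-methylethoxy group from that carbonyl carbon. The step to the (tert-butyl)sulfanyl group was a number 21 percentage points lower from compound 1 to compound 2 (beyond the scatter), and the step to the 1-fluoro-1-methylethyl group was a number 23 percentage points lower from compound 1 to compound 3 (beyond the scatter). Between those two replacements the difference was a number 2 percentage points lower from compound 2 to compound 3 (within the scatter), so the size of the drop did not depend much on which group entered. The 1,1-difluoropropyl group of compound 4 is, like that of compound 3, a fluorine-bearing chain joined directly to the carbonyl carbon, so a drop of similar size is expected, namely a number 21 percentage points lower from compound 1 to compound 4 (beyond the scatter). Compound 4 is therefore estimated to reach 76% in this assay, within a range from 62% to 90%.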

Compound 4, largest response reached (reported as efficacy), in percent of the reference or control that the assay uses: 90%
Compound 4: the middle estimate sits 14 percentage points below what was measured, and the stated range covers the measured number.
By their numbers in this assay, from the lowest: compounds 3 and 2 (each within the scatter of the next); then compounds 4 and 1 (each within the scatter of the next).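

The earlier compounds shown here suggested that losing the 1-cyano-1-methylethoxy group from this carbonyl carbon costs response, but compound 4 shows that this is not always so: in this assay the change to 1,1-difluoropropyl gives a number 7 percentage points lower from compound 1 to compound 4 (within the scatter) and so leaves the response level with that of compound 1. The drop seen with the other two replacements therefore belongs to those groups and not to the loss of the 1-cyano-1-methylethoxy group alone. This position also separates two fluorine-bearing groups joined directly to the carbonyl carbon, since the result is a number 16 percentage points higher from compound 3 to compound 4 (beyond the scatter) and, against the sulfur-linked group, a number 14 percentage points higher from compound 2 to compound 4 (beyond the scatter) as well; nothing measured here explains these differences.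

From the compounds shown here alone, what remains open is how much of the response of compound 4 depends on its fluorine atoms and how much on its chain. A plain propyl group, a trifluoromethyl group, a longer chain such as 1,1-difluorobutyl or an amine on the same carbonyl carbon would each help to separate these contributions.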